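From methoxy to hydroxy: a step without a measured precedent

A few compounds are considered here, and "the series" means these few. Any claim that something is new, unique, unknown or untested is made for them only; others in the source may bear on it.

Measured compounds:
compound 1, `O=C(N/N=C/c1ccccc1)c1cnccn1`, giving 75%
compound 2, `O=C(N/N=C/c1ccc(F)cc1)c1cnccn1`, giving 69%
compound 3, `COc1ccc(/C=N/NC(=O)c2cnccn2)cc1`, giving 55%

In an ADME assay on J774 cells (Mus musculus) for cytotoxicity, read by MTT assay, with a stated time of 48 h, tested at 100 ug/mL (a higher number here means a weaker effect of the compound at the concentration tested, a lower number a stronger effect), compound 3 gives 55%, the lowest of the three numbers. The step of a number 20 percentage points lower from compound 1 to compound 3 (beyond the scatter) and the step of a number 14 percentage points lower from compound 2 to compound 3 (beyond the scatter) both lie beyond the scatter, whereas the step of a number 6 percentage points lower from compound 1 to compound 2 (within the scatter) lies within it. Compound 4, `O=C(N/N=C/c1ccc(O)cc1)c1cnccn1`, has not been measured in this assay. It differs from compound 3 in one place: hydrogen in place of methyl on an oxygen on an aromatic ring.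

Among the compounds with values here, none of the measured steps bears directly on this change. All three steps exchange what sits on an aromatic carbon; none removes a methyl from an oxygen. The two steps that reached beyond the scatter, a number 20 percentage points lower from compound 1 to compound 3 (beyond the scatter) and a number 14 percentage points lower from compound 2 to compound 3 (beyond the scatter), were modest. Within the data shown here, no measured step here is large. With no measured guide to its direction, the expectation stays close to compound 3 and the range is kept wide enough to cover the other two numbers.

Compound 4 is expected to give 60%, within a range from 45% to 78%. The step that this estimate means, a number 5 percentage points higher from compound 3 to compound 4 (within the scatter), is expected to stay within the scatter.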

Compound 4, a percentage reported as activity, at one concentration (the size of the read-out at that concentration, not a potency): 81%
Beside the measured number, compound 4's estimate is 21 percentage points below it; measured number outside the range, above it.
By their numbers in this assay, from the lowest: compound 3; then compounds 2, 1 and 4 (each within the scatter of the next, the first and the last beyond it).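

In this assay, within the data shown here, the oxygen on the aromatic ring proves sensitive to what it carries: taking off the methyl alone gives a number 26 percentage points higher from compound 3 to compound 4 (beyond the scatter) and is the first change here made at that oxygen rather than on an aromatic carbon. The hydroxy group also parts from fluoro with a number 12 percentage points higher from compound 2 to compound 4 (beyond the scatter) while the hydroxy compound shows a number 6 percentage points higher from compound 1 to compound 4 (within the scatter) and so stays within the scatter of hydrogen, which leaves methoxy as the only group shown that stands beyond the scatter from hydrogen. Nothing in the available evidence accounts for this result.

From the compounds shown here alone, it remains open whether an ethyl or a longer chain on the same oxygen would read like methoxy or like hydroxy. Going by these compounds, it also remains open whether an amine or a carboxylic acid on the same aromatic carbon would stay within the scatter of compound 1 and whether the methoxy to hydroxy change would give a similar step elsewhere on the shared core.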